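Swapping fluoro for methoxy on the sulfonyl aryl ring

This account rests on a few compounds, and the source may have more. Where it says the series, first, only, none or still open, it means among the compounds named here.

Measured compounds:
- compound 1, `COc1ccc(S(=O)(=O)c2cnc3cc(F)ccc3c2-c2ccc(Cl)cc2)cc1`: 1.28 mL/min
- compound 2, `O=S(=O)(c1ccc(F)c(Cl)c1)c1cnc2cc(F)ccc2c1-c1ccc(F)cc1`: 0.69 mL/min
- compound 3, `O=S(=O)(c1ccc(F)cc1)c1cnc2cc(F)ccc2c1-c1ccc(F)cc1`: 1.34 mL/min

In an ADME assay on microsomes from liver (Homo sapiens) for metabolic stability, tested at 2.5 uM (a higher number here means faster removal of the compound, a lower number slower removal), compound 3 gives 1.34 mL/min, the highest of the three numbers, yet compound 1 sits at a value within the scatter of it, and compound 2, the lowest, is also within the scatter, so the three measured compounds are not separated here. Going by the values given here, the only single-point step on record, a 1.9-fold higher number from compound 2 to compound 3 (0.29 log units; within the scatter), is within the scatter as well.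

Compound 4, `COc1ccc(S(=O)(=O)c2cnc3cc(F)ccc3c2-c2ccc(F)cc2)cc1`, differs from compound 3 by methoxy in place of fluoro on an aromatic carbon. Among the compounds with values here, no measured pair shows exactly this exchange, so nothing bears on it directly. Compound 1 does carry the same methoxy group on the sulfonyl ring and its number is indistinguishable from that of compound 3, though compound 1 differs from compound 3 in two places, so that comparison is only indicative.

Within the data shown here, with no step pointing either way, compound 4 is expected to stay close to compound 3, a 1.0-fold lower number from compound 3 to compound 4 (0.01 log units; within the scatter). The estimate for compound 4 in this assay is 1.3 mL/min, with a range from 0.65 mL/min to 2.6 mL/min.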

Compound 4, intrinsic clearance in a liver preparation (reported as CLH), per the amount of preparation that the assay uses: 1.71 mL/min
Beside the measured number, compound 4's estimate is 1.3-fold (0.12 log units) below it; low and high end bracket the measured number.
By their numbers in this assay, from the lowest: compounds 2, 1, 3 and 4 (each within the scatter of the next, the first and the last beyond it).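

In this assay, the direct exchange of fluoro for methoxy, para to a large group, gives a 1.3-fold higher number from compound 3 to compound 4 (0.11 log units; within the scatter), so the two groups cannot be told apart at this position. Keeping methoxy there, the exchange of chloro for fluoro on an aromatic carbon gives a 1.3-fold higher number from compound 1 to compound 4 (0.13 log units; within the scatter), and this change also leaves the compounds unseparated. The wider change, 4-methoxyphenyl in place of 3-chloro-4-fluorophenyl on the sulfonyl sulfur, gives a 2.5-fold higher number from compound 2 to compound 4 (0.39 log units; beyond the scatter), a modest step that is the first among these compounds to lie beyond the scatter.

No supporting measurement accounts for any of these numbers. As far as these compounds go, whether an amine, a carboxylic acid or a longer chain such as ethoxy at this position would move the number beyond the scatter remains open.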